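The compounds below may be only part of what the source reports. "The series", "measured", "known", "first", "only" and "open" are said of these compounds alone.

The measured compounds and their values in a functional assay on A-431 cells (Homo sapiens) for cytotoxicity, read by MTT assay, with a stated time of 48 h; on this read-out lower numbers stand for stronger inhibition and higher numbers for weaker inhibition:

Compound 1, `CCCCCCCCCCCCCCNC(=O)[C@@H](NS(=O)(=O)c1cccs1)[C@@H](C)O`, gives 22000 nM.
Compound 2, `CCCCCCCCCCCCCCNC(=O)[C@@H](NS(=O)(=O)c1ccc2ccccc2c1)[C@@H](C)O`, gives 19600 nM.
Compound 3, `CCCCCCCCCCCCCCCCCCNC(=O)[C@@H](NS(=O)(=O)c1cccs1)[C@@H](C)O`, reaches only the limit of the assay, > 200000 nM, which is not a number.

Compound 1 and compound 2 share one core and differ in a single place: naphthalen-2-yl in place of thiophen-2-yl on a sulfonyl sulfur. In this assay that change gave a 1.1-fold lower number from compound 1 to compound 2 (0.05 log units; within the scatter), so the two values are within the scatter of each other and cannot be ordered.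

Compound 3 differs from compound 1 in the chain: butyl in place of hydrogen on a saturated chain carbon, ten or more bonds along the chain from an amide-type nitrogen. This change gave an at least 9.0-fold higher number from compound 1 to compound 3 (0.95 log units; beyond the scatter). Compound 3 sits at the limit of > 200000 nM in this assay, at which 1 of the 3 values shown sits, so only a limit is known for it, and the true size of that step could be larger.

Compound 4, `CCCCCCCCCCCCCCCCCCNC(=O)[C@@H](NS(=O)(=O)c1ccc2ccccc2c1)[C@@H](C)O`, has not been measured. It differs from compound 3 by naphthalen-2-yl in place of thiophen-2-yl on a sulfonyl sulfur, which is the same change, at the same place, as that from compound 1 to compound 2. Because that earlier step was a 1.1-fold lower number from compound 1 to compound 2 (0.05 log units; within the scatter), the step from compound 3 to compound 4 is also expected to be small, roughly a step that the limit leaves unreadable from compound 3 to compound 4. Compound 4 is therefore estimated at 250000 nM in this assay, with a likely range from 100000 nM to 600000 nM. Compound 4 is expected, most probably, to return only a limit again.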

Compound 4, half-maximal inhibitory concentration: 23700 nM
Beside the measured number, compound 4's estimate is 11-fold (1.02 log units) above it; measured number outside the range, below it.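

In this assay, the step of an at least 8.4-fold lower number from compound 3 to compound 4 (0.92 log units; beyond the scatter) does not match the earlier step for the same swap of thiophen-2-yl for naphthalen-2-yl, so the swap does not carry over at one size from the core of compound 1 to the core of compound 3: the same change on two cores in this assay, a 1.1-fold lower number (0.05 log units; within the scatter) from compound 1 to compound 2 and an at least 8.4-fold lower number (0.92 log units; beyond the scatter) from compound 3 to compound 4, at least 7.5-fold (0.87 log units) apart, beyond the scatter of two such steps

Read the other way, adding butyl to the chain gives a 1.2-fold higher number from compound 2 to compound 4 (0.08 log units; within the scatter), so that change does not carry over at one size either, and its outcome here differs with the group on the sulfonyl sulfur: the same change on two cores in this assay, an at least 9.0-fold higher number (0.95 log units; beyond the scatter) from compound 1 to compound 3 and a 1.2-fold higher number (0.08 log units; within the scatter) from compound 2 to compound 4, at least 7.5-fold (0.87 log units) apart, beyond the scatter of two such steps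

Compound 3 is known only through a limit, so the gaps above are minimum sizes, and these four compounds show that the two changes depend on each other without showing why: the limit of > 200000 nM in this assay, at which 1 of the 4 values shown sits.

The compounds shown leave open how a phenyl or a furan-2-yl group on the sulfonyl sulfur would read on the core of compound 3. They also leave open how thiophen-2-yl and naphthalen-2-yl would compare on a chain of intermediate length or on a still longer chain.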